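Positional shift of a chlorine on a cyclic sulfonamide

The source may report more compounds than this note shows. Statements on the series, on what has been measured and on what is new or still open speak of the compounds shown alone.

Compound 1 `Cc1ccc(CN2c3ccccc3C(=O)N(Cc3ccccc3)S2(=O)=O)cc1`: 63000 nM
Compound 2 `O=C1c2ccccc2N(Cc2ccccc2Cl)S(=O)(=O)N1Cc1ccccc1Cl`: 56000 nM
Compound 3 `O=C1c2ccccc2N(Cc2ccc(Cl)cc2)S(=O)(=O)N1Cc1ccccc1`: 60000 nM

These three compounds were tested in a functional assay on MRC5 cells (Homo sapiens); a higher number here means that more compound is tolerated, a lower number that less compound is tolerated. Compound 3 stands second highest of the three numbers, but its neighbours on either side, compound 1 and compound 2, lie within the usual scatter of it, so no order among them can be read. Going by the values given here, the only single-point step measured, a 1.1-fold lower number from compound 1 to compound 3 (0.02 log units; within the scatter), is likewise within the scatter.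

Compound 4 `O=C1c2ccccc2N(Cc2ccccc2Cl)S(=O)(=O)N1Cc1ccccc1` differs from compound 3 in this way: 2-chlorophenyl in place of 4-chlorophenyl on a saturated chain carbon bound to a sulfonamide nitrogen in a ring. Among the compounds with values here, no measured step bears directly on this change. Within the data shown here, compound 2, which also bears 2-chlorophenyl groups, gives a value within the scatter of compound 3, and nothing among the measured compounds points to a shift beyond the scatter in this assay. For compound 4 the step is therefore expected to be a 1.0-fold lower number from compound 3 to compound 4 (0.01 log units; within the scatter), that is, no change beyond the scatter. Compound 4 is estimated at 58000 nM, with a range from 35000 nM to 95000 nM.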

Compound 4, half-maximal cytotoxic concentration: 60000 nM
Compound 4: middle estimate off by 1.0-fold (0.01 log units), on the low side, within the range that was stated.
By their numbers in this assay, from the lowest: compounds 2, 3, 4 and 1 (each within the scatter of the next).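

In this assay, the change from 4-chlorobenzyl to 2-chlorobenzyl on this sulfonamide nitrogen gives no change at the digits printed from compound 3 to compound 4 (within the scatter), so at this place the two chlorine placements cannot be told apart. Going by these compounds alone, compound 4 also gives the first reading of hydrogen in place of one chloro of compound 2 (a 1.1-fold higher number from compound 2 to compound 4 (0.03 log units; within the scatter)), and that step too shows no change that can be read. The same holds for 2-chlorophenyl in place of 4-methylphenyl (a 1.1-fold lower number from compound 1 to compound 4 (0.02 log units; within the scatter)), and no measured evidence accounts for these results.

All four compounds carry only chloro or methyl groups on their benzyl rings, or no such group. From the compounds shown here alone, whether an amine or a carboxylic acid on those rings, or a longer chain in place of benzyl, would move the number beyond the scatter stays open.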